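The compounds below may be only part of what the source reports. "The series", "measured", "known", "first", "only" and "open" are said of these compounds alone.

Three analogues share one core and differ only in the group on the terminal phenyl of the urea. Compound 1 `COc1cc2cc(Oc3ccc(NC(=O)Nc4ccccc4)cc3)c(C)nc2cc1OC` carries an unsubstituted phenyl and in a functional assay on SW-620 cells (Homo sapiens) for inhibition, read by sulforhodamine B assay, with a stated time of 48 h, tested at 10 uM (on this read-out lower numbers stand for a stronger effect and higher numbers for a weaker effect at the one concentration tested), gives 105%. Compound 2 `COc1cc2cc(Oc3ccc(NC(=O)Nc4ccc(C)cc4)cc3)c(C)nc2cc1OC` bears a methyl and in this assay gives 107%; the step of a number 2 percentage points higher from compound 1 to compound 2 (within the scatter) stays within the scatter. Compound 3 `COc1cc2cc(Oc3ccc(NC(=O)Nc4cccc(C(F)(F)F)c4)cc3)c(C)nc2cc1OC` bears a trifluoromethyl and in this assay gives 17.5%, the lowest of the three numbers, with a number 87.5 percentage points lower from compound 1 to compound 3 (beyond the scatter) and a number 89.5 percentage points lower from compound 2 to compound 3 (beyond the scatter) both far beyond the scatter.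

Compound 4 `COc1cc2cc(Oc3ccc(NC(=O)Nc4ccc(Cl)c(C(F)(F)F)c4)cc3)c(C)nc2cc1OC` is compound 3 with one more change: chloro in place of hydrogen on an aromatic carbon. Read one bond further out, the 3-(trifluoromethyl)phenyl becomes a 4-chloro-3-(trifluoromethyl)phenyl. Going by the values given here, no measured step exchanges hydrogen for chloro, so the two steps onto this ring are the only guide: the methyl step was within the scatter, the trifluoromethyl step was large. Since compound 3 already sits at 17.5%, little room remains for a further fall in this assay, and a step of a number 5.5 percentage points lower from compound 3 to compound 4 (within the scatter) is expected. Compound 4 is therefore estimated at 12% in this assay, between 2% and 35%.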

Compound 4, a percentage reported as activity, at one concentration (the size of the read-out at that concentration, not a potency): 7.51%
Estimate against measurement, compound 4: 4.5 percentage points above; the measured number falls inside the stated range.
By their numbers in this assay, from the lowest: compounds 4 and 3 (each within the scatter of the next); then compounds 1 and 2 (each within the scatter of the next).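

Chloro para to a large group and ortho to a trifluoromethyl group is the first exchange of hydrogen for chloro seen on this ring, and in this assay the result is a number 10 percentage points lower from compound 3 to compound 4 (within the scatter), so this added chloro does not separate the two compounds on this read-out. The 4-chloro-3-(trifluoromethyl)phenyl stays far from the other two rings, with a number 97.5 percentage points lower from compound 1 to compound 4 (beyond the scatter) and a number 99.5 percentage points lower from compound 2 to compound 4 (beyond the scatter), which means that among these four compounds the low numbers belong only to the two rings that carry a trifluoromethyl group. Nothing available here accounts for the size of any of these steps.

The compounds shown leave open what chloro does on this ring without the trifluoromethyl group, and how a methoxy group, a nitrile or an amine would read at the same position. On these data alone, the read-out also comes from a single concentration, so it remains open whether compound 3 and compound 4 would differ in a full concentration series.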